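Ethoxy in place of methoxy on a sulfonylurea aorta series

This account rests on a few compounds, and the source may have more. Where it says the series, first, only, none or still open, it means among the compounds named here.

Of the compounds shown here, three sharing one core have been tested in a functional assay on thoracic aorta (Rattus norvegicus, strain Wistar), with a stated time of 15 min; on this read-out higher numbers stand for an effect only at larger amounts of compound and lower numbers for an effect already at smaller amounts. Compound 1 `CCOc1ccc(F)cc1C(C)NC(=O)N(C)S(=O)(=O)c1ccc(C)cc1` carries a fluorine on its core ring and gives 7800 nM. Compound 2 `CCOc1ccc(Cl)cc1C(C)NC(=O)N(C)S(=O)(=O)c1ccccc1` carries a chlorine and an unsubstituted sulfonyl-bearing ring and gives 10500 nM. Compound 3 `COc1ccc(Cl)cc1C(C)NC(=O)N(C)S(=O)(=O)c1ccc(C)cc1` carries a chlorine together with a methoxy group and gives 13800 nM. Compound 3 stands at the highest of the three numbers, yet its distance to compound 2 and to compound 1 both lie inside the usual scatter, so the three values cannot be told apart with confidence.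

Compound 4 `CCOc1ccc(Cl)cc1C(C)NC(=O)N(C)S(=O)(=O)c1ccc(C)cc1` has not yet been tested in this assay . Relative to compound 3 the change is methyl in place of hydrogen on a saturated chain carbon bound to an oxygen on an aromatic ring. Compound 1 and compound 2 already carry the ethoxy group and sit close to compound 3 on the numbers, which gives no sign that this change moves the read-out far.

The step from compound 3 to compound 4 is therefore expected to be small, most likely no larger than the scatter, with a slight lean toward a lower number, as given by a 1.5-fold lower number from compound 3 to compound 4 (0.16 log units; within the scatter). Compound 4 is estimated at 9500 nM, within a range from 4000 nM to 22000 nM.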

Compound 4, half-maximal effective concentration: 12200 nM
The estimate for compound 4 lay 1.3-fold (0.11 log units) below the measured number; the measured number falls inside the stated range.
By their numbers in this assay, from the lowest: compounds 1, 2, 4 and 3 (each within the scatter of the next).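

In this assay, the methoxy to ethoxy change can now be read on its own, with the rest of the molecule held fixed, and it gives a 1.1-fold lower number from compound 3 to compound 4 (0.05 log units; within the scatter). Compound 4 also makes two other single changes readable: methyl in place of hydrogen on an aromatic carbon gives a 1.2-fold higher number from compound 2 to compound 4 (0.07 log units; within the scatter), and chloro in place of fluoro on an aromatic carbon gives a 1.6-fold higher number from compound 1 to compound 4 (0.19 log units; within the scatter). So in these four compounds, none of the three changes moves the read-out beyond the scatter, and no further data here bear on why the picture is this flat.

On these data alone, it remains open whether a longer chain such as butoxy, or a hydroxyl group, in place of the ethoxy group would leave the number within the scatter or shift it clearly. Going by these compounds alone, also open is whether an amine or a carboxylic acid in place of the methyl on the aromatic carbon, or bromo in place of chloro, would produce the first clear step.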